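The source may report more compounds than this note shows. Statements on the series, on what has been measured and on what is new or still open speak of the compounds shown alone.

The measured compounds:

Compound 1, `O=S(=O)(Nc1ccc(-c2nc3ccccc3o2)cc1)c1ccccc1O`, in an ADME assay on HEK293 cells (Homo sapiens) for cytotoxicity, read by resazurin assay, with a stated time of 48 h; a higher number here means that more compound is tolerated, a lower number that less compound is tolerated: > 100000 nM
Compound 2, `O=S(=O)(Nc1ccc2oc(-c3ccccc3)nc2c1)c1cccc(F)c1`, in this assay: 68000 nM

Compound 1 stands only at a limit in this assay: its value of > 100000 nM is a limit of the assay and not a number, as the limit of > 100000 nM in this assay, at which 1 of the 2 values shown sits, records. For the measured compounds named here, compound 2 is the one measured compound with a numeric value, giving 68000 nM in this assay. Going by the values given here, compound 1 and compound 2 differ in more than one place, so no single step joins them; the two values only show that both compounds are tolerated by the cells up to high concentrations.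

Compound 3, `COc1cccc(S(=O)(=O)Nc2ccc(-c3nc4ccccc4o3)cc2)c1`, is not yet measured. It departs from compound 1 by one change: 3-methoxyphenyl in place of 2-hydroxyphenyl on a sulfonyl sulfur. Among the compounds with values here, no comparable step between measured compounds exists to set the size of this change. In this assay the account expects no step beyond the usual scatter, the methoxy-bearing compound remaining as well tolerated as the hydroxy-bearing one. Compound 3 is therefore estimated at 85000 nM, within a range from 35000 nM to 200000 nM. The step from compound 1 to compound 3 implied by this estimate is an at least 1.1-fold lower number from compound 1 to compound 3 (0.07 log units; that floor lies within the scatter), and is expected to lie within the scatter.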

Compound 3, half-maximal cytotoxic concentration: > 100000 nM
Compound 3: a limit, no number; the forecaster's own chance of this, stated with the estimate: 45%; at least 1.1-fold (0.07 log units) between middle value and limit.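

In this assay compound 3 gives > 100000 nM, which is a limit and not a number. For the compounds shown here, no step from compound 1 to compound 3 can be read, because both compounds stand at the same limit: the limit of > 100000 nM in this assay, at which 2 of the 3 values shown sit. The compounds shown leave open whether 3-methoxyphenyl in place of 2-hydroxyphenyl on a sulfonyl sulfur alters how much compound is tolerated.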